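Swapping the Indole Substituent on the Cyclohexene Core

The source may hold more compounds than are shown below. What is called first, only, known or untested is meant among the compounds shown, and "the series" means these compounds.

Measured so far:
compound 1, `Cc1[nH]c2ccccc2c1C1=CCC(NCc2ccc(OCC(=O)NO)cc2F)CC1`: 99 nM in a functional assay on HCT-116 cells (Homo sapiens) for antiproliferative activity, with a stated time of 72 h; a higher number here means a weaker inhibitor, a lower number a stronger inhibitor
compound 2, `O=C(COc1ccc(C(=O)N2CC=C(c3c[nH]c4ccc(F)cc34)CC2)cc1)NO`: > 5000 nM in this assay

Within the data shown here, compound 1 gives 99 nM in this assay, and it is the only plain number in the set. Compound 2 gives only a limit in this assay, > 5000 nM, not a measured number. The set therefore holds one number and one limit, (the limit of > 5000 nM in this assay, at which 1 of the 2 values shown sits). Among the measured compounds shown here, compound 2 differs from compound 1 in more than one place, so the two values show only that compound 1 is potent and compound 2 is not measurably so.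

Compound 3, `O=C(COc1ccc(CNC2CC=C(c3c[nH]c4ccc(F)cc34)CC2)c(F)c1)NO`, keeps the core of compound 1 and changes one group: 5-fluoro-1H-indol-3-yl in place of 2-methyl-1H-indol-3-yl on a double-bonded ring carbon. For the measured compounds named here, no measured pair shows this change on its own, so its size is not known from the data. The change is expected to cost some potency, a 3.0-fold higher number from compound 1 to compound 3 (0.48 log units; beyond the scatter), a step probably beyond the scatter but not large. Compound 3 is therefore estimated at 300 nM in this assay, with a range from 80 nM to 1500 nM.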

Compound 3, half-maximal inhibitory concentration: 261 nM
Beside the measured number, compound 3's estimate is 1.1-fold (0.06 log units) above it; low and high end bracket the measured number.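

Among these compounds, replacing 2-methyl-1H-indol-3-yl with 5-fluoro-1H-indol-3-yl on a double-bonded ring carbon is the first change in this set that can be read on its own, and in this assay it gives a 2.6-fold higher number from compound 1 to compound 3 (0.42 log units; beyond the scatter) as a real but modest loss. The position therefore accepts a different indole substituent pattern on the shared core, with compound 3 still giving 261 nM as a plain measured number rather than a limit. Nothing measured here accounts for the size of this step.

As far as these compounds go, the step also combines two edits, the loss of the methyl group and the gain of the fluorine, so the share of each in the loss remains open. Compounds carrying the plain 1H-indol-3-yl group or 2-methyl-5-fluoro-1H-indol-3-yl would separate the two edits, while a chlorine, a methoxy group or an amine in place of the fluorine would show whether other groups at that spot on the indole give a similar number.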